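A few compounds are considered here, and "the series" means these few. Any claim that something is new, unique, unknown or untested is made for them only; others in the source may bear on it.

Compound 1 `CNC(=O)C[C@@H]1C[C@@H](c2ccc(Cl)c(Cl)c2)[C@H](NC(=O)c2cc(-c3c(Cl)cnn3C)c(Cl)o2)CN1`: 450 nM
Compound 2 `Cn1ncc(Cl)c1-c1cc(C(=O)N[C@@H]2CN[C@H](CCCO)C[C@H]2c2ccc(Cl)c(Cl)c2)oc1Cl`: 510 nM
Compound 3 `Cn1ncc(Cl)c1-c1cc(C(=O)N[C@@H]2CN[C@H](CCO)C[C@H]2c2ccc(F)c(F)c2)oc1Cl`: 360 nM

All three values come from a functional assay on HCT-116 cells (Homo sapiens) for antiproliferative activity, read by sulforhodamine B assay, with a stated time of 72 h; on this read-out lower numbers stand for stronger inhibition and higher numbers for weaker inhibition. They lie within the usual scatter of one another, so compound 1 cannot be separated from compound 2 or compound 3 on these numbers.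

Compound 4 `Cn1ncc(Cl)c1-c1cc(C(=O)N[C@@H]2CN[C@H](CC(=O)O)C[C@H]2c2ccc(Cl)c(Cl)c2)oc1Cl` has not yet been measured. It keeps the core of compound 1 and makes one change: hydroxy in place of methylamino on a carbonyl carbon. In words, this is hydroxy in place of methylamino on a carbonyl carbon, which turns methylcarbamoyl into carboxy.

Among the measured compounds shown here, only one measured step touches this part of the molecule: a 1.1-fold higher number from compound 1 to compound 2 (0.05 log units; within the scatter). In that step, 2-hydroxyethyl replaces methylcarbamoyl, and the size of the step stays within the scatter. Compound 3 differs from compound 1 in more than one place, so it offers no clean comparison.

For the measured compounds named here, no measured compound here carries a carboxy group, which makes that single step a weak guide. A modest shift towards weaker inhibition in this assay is a cautious expectation, and the data cannot rule out no shift at all. The expected change is an estimated 2.2-fold higher number from compound 1 to compound 4 (0.35 log units; beyond the scatter). For compound 4 the estimated value is 1000 nM, with an expected range from 300 nM to 4000 nM.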

Compound 4, half-maximal inhibitory concentration: 4020 nM
For compound 4 the middle estimate is 4.0-fold (0.60 log units) below the measured one; measured number outside the range, above it.
By their numbers in this assay, from the lowest: compounds 3, 1 and 2 (each within the scatter of the next); then compound 4.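

In this assay, among the compounds shown here, hydroxy in place of methylamino on a carbonyl carbon, which turns methylcarbamoyl into carboxy, is the first change to this side chain that moves the number beyond the scatter: it gives an 8.9-fold higher number from compound 1 to compound 4 (0.95 log units; beyond the scatter). Putting carboxy in place of 2-hydroxyethyl gives a similar result, a 7.9-fold higher number from compound 2 to compound 4 (0.90 log units; beyond the scatter), whereas 2-hydroxyethyl in place of methylcarbamoyl gave only a 1.1-fold higher number from compound 1 to compound 2 (0.05 log units; within the scatter), so these three compounds show that this side chain is not indifferent to its end group, with carboxy on the side of weaker inhibition and the other two groups not separable. Nothing measured here explains why this single-atom-for-group exchange has so large an effect on the cell read-out.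

The compounds shown leave open whether the loss belongs to the carboxy group itself or would also appear with other replacements at the same carbonyl carbon, such as a methyl ester or an unsubstituted amide. They also leave open how an amine at the end of this chain would behave, and whether a longer chain ending in a carboxylic acid would give a similar number.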